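Amine tail swap on the shared core

This account rests on a few compounds, and the source may have more. Where it says the series, first, only, none or still open, it means among the compounds named here.

compound 1 `CCN(CC)CCCOc1cc2ncnc(Nc3nc4ccc(C(=O)Nc5c(C)cccc5Cl)cc4s3)c2cc1OC`: 11700 nM
compound 2 `COc1cc2c(Nc3nc4ccc(C(=O)Nc5c(C)cc(C)cc5C)cc4s3)ncnc2cc1OCCCN1CCC(C)CC1`: 7000 nM

In a functional assay on DLD-1 cells (Homo sapiens) for cytotoxicity, read by WST assay, with a stated time of 72 h (a lower number here means a stronger inhibitor, a higher number a weaker inhibitor), compound 2 gives the lower of the two numbers shown, but compound 1 sits within the scatter of it, so no order between the two can be claimed. Compound 3 `CCN(CC)CCCOc1cc2ncnc(Nc3nc4ccc(C(=O)Nc5c(C)cc(C)cc5C)cc4s3)c2cc1OC` differs from compound 2 in one place: diethylamino in place of 4-methylpiperidin-1-yl on a saturated chain carbon, three bonds along the chain from an oxygen on an aromatic ring. Among the compounds with values here, no measured pair isolates this change; compound 1 carries diethylamino but differs from compound 2 elsewhere as well, so its value says little about the step. The change is expected to leave the number within the scatter: a 1.1-fold higher number from compound 2 to compound 3 (0.06 log units; within the scatter). Compound 3 is therefore estimated at 8000 nM, with a range from 3000 nM to 20000 nM.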

Compound 3, half-maximal inhibitory concentration: 6800 nM
The estimate for compound 3 lay 1.2-fold (0.07 log units) above the measured number; low and high end bracket the measured number.
By their numbers in this assay, from the lowest: compounds 3, 2 and 1 (each within the scatter of the next).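

In this assay, 3-(diethylamino)propyl in place of 3-(4-methylpiperidin-1-yl)propyl gives a 1.0-fold lower number from compound 2 to compound 3 (0.01 log units; within the scatter), so the open amine and the ring amine cannot be told apart at this position. On the amide-type nitrogen, 2,4,6-trimethylphenyl in place of 2-chloro-6-methylphenyl gives a 1.7-fold lower number from compound 1 to compound 3 (0.24 log units; within the scatter), which also stays within the scatter. Nothing available explains these results.

As far as these compounds go, it remains open whether a morpholine, a carboxylic acid or a longer chain on this oxygen would move the number beyond the scatter.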